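Benzyladenosines: hydroxyl substitution on the benzyl ring

The source may hold more compounds than are shown below. What is called first, only, known or untested is meant among the compounds shown, and "the series" means these compounds.

Measured compounds:
- compound 1 `COc1cccc(CNc2ncnc3c2ncn3[C@@H]2O[C@H](CO)[C@@H](O)[C@H]2O)c1`: > 166000 nM
- compound 2 `OC[C@H]1O[C@@H](n2cnc3c(NCc4ccc(F)c(F)c4F)ncnc32)[C@H](O)[C@@H]1O`: > 166000 nM
- compound 3 `COc1cccc(CNc2ncnc3c2ncn3[C@@H]2O[C@H](CO)[C@@H](O)[C@H]2O)c1O`: 27900 nM

Working notes. In a functional assay on K562 cells (Homo sapiens) for antiproliferative activity, with a stated time of 72 h (on this read-out higher numbers stand for weaker inhibition and lower numbers for stronger inhibition), compound 1 gives only a limit, > 166000 nM, with no number below it. Compound 2 likewise gives only a limit in this assay, > 166000 nM, so the step that the two limits leave unreadable from compound 1 to compound 2 cannot be read. Compound 3 does return a number in this assay, 27900 nM, and the step of an at least 5.9-fold lower number from compound 1 to compound 3 (0.77 log units; beyond the scatter) is the one that bears on the present question; an at least 5.9-fold lower number from compound 2 to compound 3 (0.77 log units; beyond the scatter) points the same way. The common feature is the limit of > 166000 nM in this assay, at which 2 of the 3 values shown sit.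

The unmeasured compound 4 `OC[C@H]1O[C@@H](n2cnc3c(NCc4cccc(O)c4O)ncnc32)[C@H](O)[C@@H]1O` differs from compound 1 by 2,3-dihydroxyphenyl in place of 3-methoxyphenyl on a saturated chain carbon bound to a nitrogen on an aromatic ring. Going by the values given here, it keeps the hydroxy that carried compound 3 off the limit and exchanges the methoxy for a second hydroxy, a change for which no measured step exists here. The expectation is therefore a step at least as large as that seen for compound 3, in the same downward direction, with the methoxy-to-hydroxy part left open: an at least 5.5-fold lower number from compound 1 to compound 4 (0.74 log units; beyond the scatter) is the estimated step. For compound 4 in this assay the expected value is 30000 nM, estimated between 7000 nM and 130000 nM.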

Compound 4, half-maximal inhibitory concentration: 25800 nM
Beside the measured number, compound 4's estimate is 1.2-fold (0.07 log units) above it; the range from low to high includes it.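

Hydrogen in place of methyl on the oxygen gives a 1.1-fold lower number from compound 3 to compound 4 (0.03 log units; within the scatter) in this assay, so the methoxy of compound 3 and the second hydroxy of compound 4 cannot be told apart on this read-out. The 2,3-dihydroxyphenyl group also separates clearly from both groups that lack a hydroxy, with an at least 6.4-fold lower number from compound 1 to compound 4 (0.80 log units; beyond the scatter) against 3-methoxyphenyl and an at least 6.4-fold lower number from compound 2 to compound 4 (0.80 log units; beyond the scatter) against 2,3,4-trifluorophenyl. Compound 1 and compound 2, the two without a hydroxy on the aromatic ring, remain at a limit and give no number: the limit of > 166000 nM in this assay, at which 2 of the 4 values shown sit.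

The compounds shown leave open whether a lone hydroxy without the methoxy would also give a number, and whether an amine or a carboxylic acid could replace the hydroxy. The full size of the steps from compound 1 and compound 2 also stays unread, and the step between those two cannot be read.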